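A few compounds are considered here, and "the series" means these few. Any claim that something is new, unique, unknown or untested is made for them only; others in the source may bear on it.

Working notes on the series. Three compounds with a shared core have a result in a functional assay on HCT-116 cells (Homo sapiens) for antiproliferative activity; on this read-out lower numbers stand for an effect already at smaller amounts and higher numbers for an effect only at larger amounts of compound. Compound 1 `CC(=O)N1CCc2c(C)c3c(n2-c2ccc(C(N)=O)c(c2)N[C@@H](C)CC1)CC(C)(C)CC3=O` gives 151 nM. Compound 2 `Cc1c2c(n3c1CCCNC(=O)C[C@H](C)Nc1cc-3ccc1C(N)=O)CC(C)(C)CC2=O` gives 3330 nM. Compound 3 `CC(=O)NCCN1CC[C@H](C)Nc2cc(ccc2C(N)=O)-n2c(c(C)c3c2CC(C)(C)CC3=O)CC1=O` is reported in this assay only as a limit, > 5000 nM. A limit marks the edge of what the assay can report and is not a number; this is the limit of > 5000 nM in this assay, at which 1 of the 3 values shown sits. Compound 3 therefore stands at the weak edge of the numbers shown, while compound 1 and compound 2 carry measured values, and its distance from compound 2 cannot be told.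

The next compound, compound 4 `Cc1c2c(n3c1CC(=O)N(CCN(C)C)CC[C@H](C)Nc1cc-3ccc1C(N)=O)CC(C)(C)CC2=O`, differs from compound 3 in a single place: dimethylamino in place of acetamido on a saturated chain carbon, two bonds along the chain from an amide-type nitrogen in a ring. Within the data shown here, no step between two measured compounds of this set is available, so the size of the change cannot be read from the data. Because compound 3 sits at a limit, > 5000 nM, the most that can be expected is a step toward stronger activity whose size is open; a step beyond the scatter is plausible, a result that again falls at the limit is also plausible. The expected step is an at least 1.2-fold lower number from compound 3 to compound 4 (0.09 log units; that floor lies within the scatter). Compound 4 is estimated at 4000 nM, with a range from 1200 nM to 12000 nM.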

Compound 4, half-maximal effective concentration: 330 nM
Beside the measured number, compound 4's estimate is 12-fold (1.08 log units) above it; the measured number lies below the stated range.
By their numbers in this assay, from the lowest: compound 1; then compound 4; then compound 2. At a limit, above all of these: compound 3.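

In this assay, among these compounds, the 2-(dimethylamino)ethyl chain in place of the 2-acetamidoethyl chain gives an at least 15-fold lower number from compound 3 to compound 4 (1.18 log units; beyond the scatter), the only step that can be read for a change in one place. The change is small by the count of atoms, with one heavy atom fewer and the carbonyl and the amide hydrogen gone, yet the read-out at this place on the chain moves beyond the scatter, so the group carried here is not indifferent for the antiproliferative read-out. Compound 3 stands at a limit, so this step is a floor and its full size remains unknown: the limit of > 5000 nM in this assay, at which 1 of the 4 values shown sits.

As far as these compounds go, whether the shift comes from losing the acetamido group or from gaining the dimethylamino group stays open, and a primary amine, a carboxylic acid or a longer chain ending in dimethylamino at the same place would be needed to separate the two readings. Steps linking compound 1 or compound 2 to compound 4 cannot be read, as these compounds differ in more than one place, and whether the same exchange would carry over to their chains is equally unsettled.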